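Chloro for fluoro in the amino ketone series

The source may report more compounds than this note shows. Statements on the series, on what has been measured and on what is new or still open speak of the compounds shown alone.

- compound 1 `Nc1ccc(/C=C/C(=O)c2ccccc2)cc1` – 10000 nM
- compound 2 `Nc1ccc(/C=C/C(=O)c2ccc(F)cc2)cc1` – 12000 nM

In a functional assay on MOLT-4 cells (Homo sapiens) for antiproliferative activity, with a stated time of 48 h (a lower number here means a stronger inhibitor, a higher number a weaker inhibitor), compound 2 gives 12000 nM, which lies within the scatter of compound 1 at 10000 nM. The two measured values therefore stand level. The next structure is compound 3 `Nc1ccc(/C=C/C(=O)c2ccc(Cl)cc2)cc1`, which carries chloro in place of fluoro on an aromatic carbon, para to a large group: chloro in place of fluoro on an aromatic carbon. Within the data shown here, only one measured step bears on this change: a 1.2-fold higher number from compound 1 to compound 2 (0.08 log units; within the scatter), with fluoro in place of hydrogen on an aromatic carbon. Among the measured compounds shown here, that step stayed within the scatter, but no measured step yet involves chloro, so the evidence is thin. No step beyond the scatter is expected in this assay, and no direction is favoured with any confidence. The estimated step is a 1.2-fold lower number from compound 2 to compound 3 (0.08 log units; within the scatter). For compound 3, the expected value is 10000 nM, with an estimated range of 4500 nM to 22000 nM.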

Compound 3, half-maximal inhibitory concentration: 7800 nM
Compound 3: the middle estimate sits 1.3-fold (0.11 log units) above what was measured; the measured number falls inside the stated range.
By their numbers in this assay, from the lowest: compounds 3, 1 and 2 (each within the scatter of the next).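

Chloro in place of fluoro gives a 1.5-fold lower number from compound 2 to compound 3 (0.19 log units; within the scatter) in this assay and chloro in place of hydrogen gives a 1.3-fold lower number from compound 1 to compound 3 (0.11 log units; within the scatter) as well. With chloro added, hydrogen, fluoro and chloro on this aromatic carbon, para to a large group, all stand level, so neither halogen separates from hydrogen or from the other halogen at this position. No measurement bears on why these three stand level.

Going by these compounds, whether a group of a different kind at this position, such as methoxy, a carboxylic acid or a longer chain, would give a step beyond the scatter stays open. On these data alone, the amine is shared by compound 1, compound 2 and compound 3, so the effect of replacing it, for instance with a hydroxyl, also stays open.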